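This account rests on a few compounds, and the source may have more. Where it says the series, first, only, none or still open, it means among the compounds named here.

Compound 1 `CC(=O)Nc1ccc(S(=O)(=O)NNC(=O)c2cccnc2Nc2ccc(Cl)cc2)cc1` was tested in a functional assay on ACHN cells (Homo sapiens) for antiproliferative activity (on this read-out lower numbers stand for higher toxicity in this test and higher numbers for lower toxicity in this test), where compound 1 gives > 100000 nM, a value that is only a limit of the assay rather than a measured number. Compound 2 `O=C(NNS(=O)(=O)c1ccc(F)cc1)c1cccnc1Nc1ccc(Cl)cc1Cl` gives > 100000 nM in this assay, again a limit. Both results so far sit at the limit of > 100000 nM in this assay, at which 2 of the 2 values shown sit. Compound 3 `O=C(NNS(=O)(=O)c1ccc(Cl)cc1Cl)c1cccnc1Nc1ccc(Cl)cc1` differs from compound 1 in one place: 2,4-dichlorophenyl in place of 4-acetamidophenyl on a sulfonyl sulfur. Within the data shown here, no measured step links such a change to a result, so the step of a number no higher from compound 1 to compound 3 (the limit leaves the size open) is expected to stay within the usual scatter. For compound 3 the estimate is 100000 nM, ranging from 30000 nM to 300000 nM.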

Compound 3, concentration lethal to 50% of the cells: > 100000 nM
Compound 3: only a limit was reported; the forecaster's own chance of this, stated with the estimate: 70%; the middle value sits exactly at the limit.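

No step can be read from compound 1 to compound 3, since both results are only limits: the limit of > 100000 nM in this assay, at which 3 of the 3 values shown sit. The compounds shown leave open whether 2,4-dichlorophenyl in place of 4-acetamidophenyl on a sulfonyl sulfur changes the result in this assay at all.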